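The source may report more compounds than this note shows. Statements on the series, on what has been measured and on what is new or still open speak of the compounds shown alone.

Notes on the series. Among the compounds with values here, in an ADME assay on the whole organism (plasma, Macaca fascicularis) for protein binding, read by LC-MS, using equilibrium dialysis and cassette dosing, with a stated time of 24 h, at a dose of 1 mg/kg by the oral route (a higher number here means a larger unbound share of the compound, a lower number a smaller unbound share), compound 1 `C[C@H](c1ccc(-c2ccccc2-c2nc(=O)o[nH]2)cc1)N(CC1CC1)c1nc2c(C(=O)O)cccc2o1` gives 0.0000851, and compound 2 `Cc1ccc(-c2nc(=O)o[nH]2)c(-c2ccc([C@@H](C)N(CC3CC3)c3nc4c(C(=O)O)cccc4o3)cc2)c1` gives 0.00023, the higher of the two numbers seen so far; the only measured step is a 2.7-fold higher number from compound 1 to compound 2 (0.43 log units; beyond the scatter), methyl in place of hydrogen. Compound 3 `C[C@H](c1ccc(-c2cc(F)ccc2-c2nc(=O)o[nH]2)cc1)N(CC1CC1)c1nc2c(C(=O)O)cccc2o1` carries fluoro in place of methyl on an aromatic carbon. Within the data shown here, no measured step covers a fluoro substituent, so the methyl step is only an indirect guide; removal of the methyl points back toward the number of compound 1, while the fluoro is unknown. Compound 3 is therefore expected to show a 1.8-fold lower number from compound 2 to compound 3 (0.25 log units; within the scatter), an estimate of 0.00013 with a range of 0.00006 to 0.0003.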

Compound 3, unbound fraction: 0.0000977
Estimate against measurement, compound 3: 1.3-fold (0.12 log units) above; low and high end bracket the measured number.
By their numbers in this assay, from the lowest: compounds 1 and 3 (each within the scatter of the next); then compound 2.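

At this aromatic carbon, meta to a large group and para to a group of 6 heavy atoms, the choice of substituent separates methyl from fluoro in this assay, with a 2.4-fold lower number from compound 2 to compound 3 (0.37 log units; beyond the scatter). Fluoro in place of hydrogen gives a 1.1-fold higher number from compound 1 to compound 3 (0.06 log units; within the scatter), so only methyl stands apart among the three groups at this position. No supporting data offer an explanation for this difference.

Going by these compounds, whether ethyl, methoxy or chloro at this carbon would follow methyl or fluoro remains open. Also open, on these data alone, is whether the methyl step would hold on a different core.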